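Fluoro for Methoxy in an Open-Chain Analogue

A few compounds are considered here, and "the series" means these few. Any claim that something is new, unique, unknown or untested is made for them only; others in the source may bear on it.

Of the compounds shown here, three have been tested in a functional assay on LoVo cells (Homo sapiens) for inhibition, read by colorimetric assay and MTT assay, with a stated time of 72 h; on this read-out lower numbers stand for stronger inhibition and higher numbers for weaker inhibition. Compound 1 `COc1ccc2c(c1)-c1cnc(n1C)OCCCCCCCCO2` gives 34000 nM. Compound 2 `Cn1c2cnc1OCCCCCCCCOc1ccc(F)cc1-2` differs from compound 1 by fluoro in place of methoxy on an aromatic carbon, and in this assay compound 2 gives 43000 nM; the step was a 1.3-fold higher number from compound 1 to compound 2 (0.10 log units; within the scatter). Compound 3 `C=CCCCCOc1ccc(OC)cc1-c1cnc(OCCC=C)n1C` gives 33000 nM; how its core differs from the core of compound 1 is not broken down here. Compound 4 `C=CCCCCOc1ccc(F)cc1-c1cnc(OCCC=C)n1C` has not been measured; it differs from compound 3 by fluoro in place of methoxy on an aromatic carbon. The surroundings differ: in compound 1 the position is part of a fused or bridged system of three rings, meta to a fused ring and para to a fused ring, whereas in compound 3 it is meta to a large group and para to a (hex-5-en-1-yl)oxy group, so this is the same kind of change, not the same change. Because the earlier step was a 1.3-fold higher number from compound 1 to compound 2 (0.10 log units; within the scatter), the step from compound 3 to compound 4 is expected to be a 1.3-fold higher number from compound 3 to compound 4 (0.10 log units; within the scatter). Compound 4 is therefore estimated to give 42000 nM, expected between 20000 nM and 90000 nM.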

Compound 4, half-maximal inhibitory concentration: 38000 nM
The estimate for compound 4 lay 1.1-fold (0.04 log units) above the measured number; the measured number falls inside the stated range.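

In this assay, putting fluoro in place of methoxy gives a 1.2-fold higher number from compound 3 to compound 4 (0.06 log units; within the scatter), so the numbers of these two compounds cannot be told apart. The same swap on the two cores gives steps that agree: the same change on two cores in this assay, a 1.3-fold higher number (0.10 log units; within the scatter) from compound 1 to compound 2 and a 1.2-fold higher number (0.06 log units; within the scatter) from compound 3 to compound 4, 1.1-fold (0.04 log units) apart, within the scatter of two such steps. This shows that, on both cores, the swap leaves the read-out within the usual scatter, but with steps this small it does not show a shared real effect that carries from one core to the other.

The compounds shown leave open whether a different group at this place, such as an amine, a carboxylic acid or a longer chain, would give a step beyond the scatter. As far as these compounds go, whether the swap behaves the same way on any further core also remains open.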